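Para substituent swap on the aryl ketone of the chalcone series

This account rests on a few compounds, and the source may have more. Where it says the series, first, only, none or still open, it means among the compounds named here.

Measured so far:
Compound 1 `COc1ccc(C(=O)/C=C/c2cc3ccccc3[nH]c2=O)cc1` gives 40100 nM in a functional assay on SK-MEL-2 cells (Homo sapiens) for cytotoxicity, read by sulforhodamine B assay, with a stated time of 24 h; a higher number here means a weaker inhibitor of growth, a lower number a stronger inhibitor of growth.
Compound 2 `O=C(/C=C/c1cc2ccccc2[nH]c1=O)c1ccc(O)cc1` gives 13600 nM in this assay.

For the measured compounds named here, compound 2 stands at the lowest of the two numbers so far; its nearest neighbour is compound 1, and the step of a 2.9-fold lower number from compound 1 to compound 2 (0.47 log units; beyond the scatter) is the only measured step. Compound 3 `O=C(/C=C/c1cc2ccccc2[nH]c1=O)c1ccc(Cl)cc1` differs from compound 2 by chloro in place of hydroxy on an aromatic carbon. Going by the values given here, no measured step bears directly on this change: the one step known concerns hydrogen in place of methyl on an oxygen at the same place, and chloro resembles neither. Among the compounds with values here, the only guidance is that both measured compounds fall within a modest span, so a small step is expected, with direction uncertain and most likely toward a higher number, giving a 1.5-fold higher number from compound 2 to compound 3 (0.17 log units; within the scatter). Compound 3 is therefore estimated at 20000 nM, with a range of 7000 nM to 60000 nM.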

Compound 3, concentration for total growth inhibition: 25700 nM
The estimate for compound 3 lay 1.3-fold (0.11 log units) below the measured number, within the range that was stated.
By their numbers in this assay, from the lowest: compounds 2, 3 and 1 (each within the scatter of the next, the first and the last beyond it).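

Chloro in place of hydroxy at this position, on the 4-hydroxyphenyl to 4-chlorophenyl change, gives a 1.9-fold higher number from compound 2 to compound 3 (0.28 log units; within the scatter) in this assay and leaves compound 3 within the scatter of the hydroxy compound despite the loss of its 1 hydrogen-bond donor. Chloro in place of methoxy gives a 1.6-fold lower number from compound 1 to compound 3 (0.19 log units; within the scatter) as well, so compound 3 cannot be separated from either neighbour, even though those two neighbours stand apart by a 2.9-fold lower number from compound 1 to compound 2 (0.47 log units; beyond the scatter) and chloro adds no resolved step of its own. Nothing measured on hand accounts for these numbers.

Going by these compounds, whether an amine, a carboxylic acid or a longer alkoxy chain on this carbon would move the number beyond the scatter stays open. On these data alone, all three numbers come from a single cell line, so whether this spacing holds in other cells also stays open.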